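The compounds below may be only part of what the source reports. "The series", "measured", "known", "first", "only" and "open" are said of these compounds alone.

Compound 1 `O=C(CCC(=O)OCCCCCCSc1ccc([N+](=O)[O-])c2nonc12)Nc1ccccc1` is the reference point of this small set. In a functional assay on 143B cells (Homo sapiens) for inhibition, read by MTT assay, with a stated time of 72 h (a lower number here means a stronger inhibitor, a higher number a weaker inhibitor), compound 1 gives 3850 nM, the highest of the two numbers in hand; its nearest neighbour is compound 2 `O=C(CCC(=O)OCCCCCCSc1ccc([N+](=O)[O-])c2nonc12)Nc1ccccc1Cl`, which in this assay gives 2430 nM. Among the compounds with values here, the one measured step, a 1.6-fold lower number from compound 1 to compound 2 (0.20 log units; within the scatter), is the only guide available. Compound 3 `Cc1ccccc1NC(=O)CCC(=O)OCCCCCCSc1ccc([N+](=O)[O-])c2nonc12` differs from compound 1 by methyl in place of hydrogen on an aromatic carbon. That single step bears on it directly, since it too is a change of hydrogen on an aromatic carbon, and it stayed within the scatter, so the methyl change is expected to move the number by a similarly small amount, if at all, with the direction open. Compound 3 is expected to give about 3000 nM in this assay, somewhere between 1500 nM and 6000 nM. The expected step of a 1.3-fold lower number from compound 1 to compound 3 (0.11 log units; within the scatter) is thus estimated to lie within the scatter.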

Compound 3, half-maximal inhibitory concentration: 4660 nM
Compound 3: middle estimate off by 1.6-fold (0.19 log units), on the low side; the range from low to high includes it.
By their numbers in this assay, from the lowest: compounds 2, 1 and 3 (each within the scatter of the next).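

With methyl on the aromatic carbon ortho to a large group, the result is a 1.2-fold higher number from compound 1 to compound 3 (0.08 log units; within the scatter) in this assay, so a second group at this place also leaves the number within the scatter. Methyl and chloro can now be set directly against each other, and a 1.9-fold higher number from compound 2 to compound 3 (0.28 log units; within the scatter), though the larger of the two new steps, is also within the scatter, so hydrogen, chloro and methyl at this place cannot be told apart in this assay. No evidence is available on what lies behind these small steps.

Open, as far as these compounds go, is whether an amine, a carboxylic acid or a methoxy group at this place would give a step beyond the scatter. Also open, from the compounds shown here alone, is how methyl would read elsewhere on the ring, or how a longer chain would read in the shared core.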